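Reversed benzylamine linker at the aryl amine position

The source may hold more compounds than are shown below. What is called first, only, known or untested is meant among the compounds shown, and "the series" means these compounds.

Measured compounds in a functional assay on CHOK cells for antagonist activity at growth hormone secretagogue receptor type 1 (Homo sapiens), read by calcium flux; a higher number here means a weaker inhibitor, a lower number a stronger inhibitor:
compound 1 `Nc1nc(N)c(-c2ccc(NCc3ccc([N+](=O)[O-])cc3)cc2)c(COCc2ccccc2)n1`: 5.8 nM
compound 2 `COc1ccc(CNc2ccc(-c3c(N)nc(N)nc3COCc3ccccc3)cc2)cc1`: 90 nM
compound 3 `CC(C)(C)CNc1ccc(-c2c(N)nc(N)nc2COCc2ccccc2)cc1`: 700 nM

Compound 3 stands highest of the three in this assay. Its nearest neighbour is compound 2, a 7.8-fold higher number from compound 2 to compound 3 (0.89 log units; beyond the scatter); furthest is compound 1, a 120-fold higher number from compound 1 to compound 3 (2.08 log units; beyond the scatter). The other measured step, a 16-fold higher number from compound 1 to compound 2 (1.19 log units; beyond the scatter), shows that the substituent on the distal aromatic ring matters on its own.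

Compound 4 `Nc1nc(N)c(-c2ccc(CNc3ccc([N+](=O)[O-])cc3)cc2)c(COCc2ccccc2)n1` is not yet measured. Its change from compound 3 is ((4-nitrophenyl)amino)methyl in place of neopentylamino on an aromatic carbon. This reverses the direction of the step from compound 1 to compound 3, which removed a 4-nitrophenyl and left a tert-butyl, but the linker between the two rings is now joined the other way round, so compound 4 is not simply compound 1 restored. The step from compound 1 to compound 3 was large; the step from compound 2 to compound 3 was modest. A large drop in the number is therefore expected for compound 4, somewhat short of recovering compound 1.

Compound 4 is estimated at 15 nM (range 3 nM to 80 nM), an expected step of a 47-fold lower number from compound 3 to compound 4 (1.67 log units; beyond the scatter).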

Compound 4, half-maximal inhibitory concentration: 16 nM
Compound 4: the middle estimate sits 1.1-fold (0.03 log units) below what was measured; the range from low to high includes it.
By their numbers in this assay, from the lowest: compound 1; then compound 4; then compound 2; then compound 3.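

In this assay, the 4-nitrophenyl group retains most of its gain over neopentylamino when joined through the reversed linker (a 44-fold lower number from compound 3 to compound 4 (1.64 log units; beyond the scatter)). Linker direction still matters, since ((4-nitrophenyl)amino)methyl does not fully match (4-nitrobenzyl)amino (a 2.8-fold higher number from compound 1 to compound 4 (0.44 log units; beyond the scatter)), a modest step beyond the scatter. The reversed nitro compound also stays ahead of the methoxy compound (a 5.6-fold lower number from compound 2 to compound 4 (0.75 log units; beyond the scatter)), but this step changes both linker direction and ring substituent, so it cannot separate their contributions.

No supporting evidence is available to explain these differences.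

The compounds shown leave open whether methoxy keeps its place behind nitro on the reversed linker. They also leave open how a nitrile or a carboxylic acid in place of nitro would behave on either linker.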